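Sulfonylated bicyclic series: notes on metabolic stability

A few compounds are considered here, and "the series" means these few. Any claim that something is new, unique, unknown or untested is made for them only; others in the source may bear on it.

Measured so far in an ADME assay on microsomes from liver (Homo sapiens) for metabolic stability, using NADPH, with a stated time of 30 min, in the presence of a further agent that is not named here; a higher number here means that more of the compound is left, a lower number that less of the compound is left:
compound 1 `CC(C)[C@H]1Cc2n[nH]cc2[C@@H](C(C)C)N1S(=O)(=O)c1ccc(C(F)(F)F)cc1` gives 10%
compound 2 `O=S(=O)(c1ccc(Cl)cc1)N1CCc2n[nH]cc2C1c1nccs1` gives 57%
compound 3 `CC(C)C1Cc2n[nH]cc2CN1S(=O)(=O)c1ccc(Cl)cc1` gives 5%

Compound 3 sits lowest of the three numbers. Its nearest neighbour is compound 1, whose value lies within the usual scatter of it, so no order between the two can be read. Compound 2 stands far above compound 3, well beyond the scatter; the two differ in more than one place, so only the two values themselves can be stated.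

Compound 4 `O=S(=O)(c1ccc(Cl)cc1)N1Cc2c[nH]nc2CC1c1cncnc1` is the next candidate. Relative to compound 3 the change is pyrimidin-5-yl in place of isopropyl on a saturated ring carbon. Going by the values given here, no single-place step between measured compounds exists from which to size this change. Among the compounds with values here, compound 2, the only measured compound without an isopropyl group, returns the highest value, whereas compound 1 and compound 3 both carry isopropyl and return low values; this observation rests on three compounds only.

On that basis a rise in this assay beyond the scatter is expected, a number 30 percentage points higher from compound 3 to compound 4 (beyond the scatter). Compound 4 is estimated at 35%, with a range from 10% to 65%.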

Compound 4, percent of the compound remaining: 67%
For compound 4 the middle estimate is 32 percentage points below the measured one, outside the stated range (above it).
By their numbers in this assay, from the lowest: compounds 3 and 1 (each within the scatter of the next); then compounds 2 and 4 (each within the scatter of the next).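

In this assay, the saturated ring carbon next to the ring nitrogen proves sensitive to its substituent: pyrimidin-5-yl in place of isopropyl gives a number 62 percentage points higher from compound 3 to compound 4 (beyond the scatter) in a single change. The earlier compounds shown here could not show this, as none of them differed in only one place, so the link between isopropyl and low values rested on compounds with other differences; here the core and the chlorinated aryl sulfonyl part stay the same, and the large step belongs to this one exchange. Nothing measured here explains why the amount of compound left changes with this exchange.

The step changes several things at once, replacing an open chain of carbon atoms with a larger aromatic ring that carries ring nitrogens, so it cannot separate the presence of a ring from the presence of those nitrogens. Phenyl or cyclopropyl on the same carbon would help to separate these features, while a single pair leaves open whether the step would be of similar size with another group on the sulfonyl aryl ring, such as trifluoromethyl.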